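The source may report more compounds than this note shows. Statements on the series, on what has been measured and on what is new or still open speak of the compounds shown alone.

The study concerns three compounds that share one core and differ only in the unsaturated amide chain. Compound 1 `CC/C=C/C(=O)Nc1cccc(Oc2nc(Nc3cccc(OC)c3)nc3ccsc23)c1` carries a straight chain in that amide. In an ADME assay on L02 cells (Homo sapiens) for inhibition, read by MTT assay, with a stated time of 72 h (a higher number here means a weaker inhibitor, a lower number a stronger inhibitor), compound 1 gives > 50000 nM, which is a limit of the assay and not a number. Compound 2 `COc1cccc(Nc2nc(Oc3cccc(NC(=O)/C=C/C(C)C)c3)c3sccc3n2)c1` carries a branched chain in the same amide. In this assay compound 2 gives "not determined" (no result reported), so no single number stands for it. Of the two values shown, one sits at the limit of > 50000 nM in this assay, at which 1 of the 2 values shown sits. Compound 3 `CCC/C=C/C(=O)Nc1cccc(Oc2nc(Nc3cccc(OC)c3)nc3ccsc23)c1` has not yet been measured. It differs from compound 2 by propyl in place of isopropyl on a double-bonded chain carbon bound to a double-bonded chain carbon. Going by the values given here, no step between measured compounds exists in this assay to calibrate this change, and with compound 1 at a limit and compound 2 without a number, no direction beyond the scatter can be supported; the step from compound 2 to compound 3 is expected to be small or none. Compound 3 is expected to give 60000 nM in this assay, within a range from 15000 nM to 200000 nM.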

Compound 3, half-maximal inhibitory concentration: > 50000 nM
Compound 3 was reported as a limit; the forecaster's own chance of this, stated with the estimate: 80%; the middle value is on the limit's open side.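

In this assay no step can be read from compound 1 to compound 3, as each stands at a limit of the assay and not at a number, and compound 2 has no reported result to set against compound 3: the limit of > 50000 nM in this assay, at which 2 of the 3 values shown sit. The compounds shown leave open whether any change in this unsaturated amide chain moves the value in this assay at all.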